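Acrylonitrile Amides in a Neuroblastoma Growth Assay

The source may hold more compounds than are shown below. What is called first, only, known or untested is meant among the compounds shown, and "the series" means these compounds.

Measured compounds:
compound 1, `N#C/C(=C\c1ccc([N+](=O)[O-])cc1)C(=O)c1c[nH]c2ccccc12`, 40000 nM
compound 2, `N#C/C(=C\c1ccc[nH]1)C(=O)NCc1ccc(Cl)c(Cl)c1`, 43000 nM
compound 3, `COc1ccc(CNC(=O)/C(C#N)=C/c2ccc3ccccc3c2)cc1`, 42000 nM

In a functional assay on BE(2)-C cells (Homo sapiens) for inhibition, read by MTT assay, with a stated time of 72 h (a lower number here means a stronger inhibitor of growth, a higher number a weaker inhibitor of growth), compound 1 gives 40000 nM. Compound 2 gives 43000 nM in this assay, and compound 3 gives 42000 nM. Compound 2 carries the highest of the three numbers, but its nearest neighbour is compound 3 and its furthest is compound 1, and both gaps lie within the scatter of this assay, so the three compounds cannot be told apart on these numbers.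

The step of interest leads to compound 4, `COc1ccc(/C=C(\C#N)C(=O)NCc2ccc(Cl)c(Cl)c2)cc1`, which is not yet measured in this assay. Compound 4 differs from compound 2 in one place: 4-methoxyphenyl in place of 1H-pyrrol-2-yl on a double-bonded chain carbon bound to a double-bonded chain carbon. The chain and the dichlorobenzylamide of compound 2 are kept.

Among the measured compounds shown here, no step between two measured compounds is available, so the account rests on the spread of the measured values. All three measured compounds, with different aryl groups on the chain and different amide or ketone ends, sit at the same level within the scatter, and compound 3 already carries a 4-methoxyphenyl in its structure at a similar value. Compound 4 is therefore expected to stay at this level; the step of a 1.1-fold lower number from compound 2 to compound 4 (0.03 log units; within the scatter) is estimated to remain within the scatter, in no particular direction. Compound 4 is estimated at 40000 nM in this assay, with a range from 15000 nM to 100000 nM.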

Compound 4, concentration for 50% growth inhibition: 93000 nM
Estimate against measurement, compound 4: 2.3-fold (0.37 log units) below, and the stated range covers the measured number.
By their numbers in this assay, from the lowest: compounds 1, 3 and 2 (each within the scatter of the next); then compound 4.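

In this assay, 4-methoxyphenyl in place of 1H-pyrrol-2-yl on a double-bonded chain carbon bound to a double-bonded chain carbon, with the chain and the dichlorobenzylamide kept, gives a 2.2-fold higher number from compound 2 to compound 4 (0.34 log units; beyond the scatter), a modest step and the only one in this set that can be read as a change in one place. It shows that this position is not indifferent to the ring it carries, something the level numbers of compound 1, compound 2 and compound 3 could not show, as those compounds differ from one another in more than one place; compound 3 also holds its methoxy-bearing ring at the amide end, not at this position. Nothing available explains the step.

The compounds shown leave open whether the step follows the departure of the 1H-pyrrol-2-yl, with its hydrogen-bond donor, or the arrival of the 4-methoxyphenyl, and a plain phenyl or a 4-hydroxyphenyl at this position would help separate the two. Also open, going by these compounds, is whether the same step appears with a different amide end, such as a morpholine amide in place of the dichlorobenzylamide.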